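Compound 3: 4-fluorophenyl replacing 3-aminophenyl on nitrogen

This account rests on a few compounds, and the source may have more. Where it says the series, first, only, none or still open, it means among the compounds named here.

In a functional assay on MCF7 cells (Homo sapiens) for cytotoxicity, read by MTT assay, with a stated time of 96 h (a lower number here means a stronger inhibitor, a higher number a weaker inhibitor), compound 1 (`COc1cc(C(=O)c2cn(-c3cccc(N)c3)cc2-c2ccccc2F)cc(OC)c1OC`) gives 17 nM and compound 2 (`COc1cc(C(=O)c2cn(-c3cccc(N)c3)cc2-c2ccc(N)cc2)cc(OC)c1OC`) gives 14 nM within the scatter of each other. Within the data shown here, the one measured step (a 1.2-fold lower number from compound 1 to compound 2 (0.08 log units; within the scatter)) lies within the scatter and sits on an aromatic carbon, not on the aromatic nitrogen. Compound 3 (`COc1cc(C(=O)c2cn(-c3ccc(F)cc3)cc2-c2ccccc2F)cc(OC)c1OC`) has 4-fluorophenyl in place of 3-aminophenyl on an aromatic nitrogen. Among the measured compounds shown here, no measured step covers this change, and both measured compounds carry 3-aminophenyl, so the direction remains a judgement. A higher number is expected, with an estimated step (an 8.8-fold higher number from compound 1 to compound 3 (0.95 log units; beyond the scatter)) beyond the scatter. Compound 3 is estimated at 150 nM with 30 nM to 800 nM as the expected range.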

Compound 3, half-maximal inhibitory concentration: 39 nM
Estimate against measurement, compound 3: 3.8-fold (0.59 log units) above; the measured number falls inside the stated range.
By their numbers in this assay, from the lowest: compounds 2 and 1 (each within the scatter of the next); then compound 3.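

The aromatic nitrogen position now has its first reading: 4-fluorophenyl in place of 3-aminophenyl gives a 2.3-fold higher number from compound 1 to compound 3 (0.36 log units; beyond the scatter), whereas the earlier step lay on an aromatic carbon and within the scatter. The amine of 3-aminophenyl is thus not essential to activity, since compound 3 still gives 39 nM. No available evidence accounts for this step.

Going by these compounds, the amine leaves and the fluorine enters in one step, so their separate contributions remain open. Unsubstituted phenyl or 3-fluorophenyl on the same nitrogen would separate them.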